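A few compounds are considered here, and "the series" means these few. Any claim that something is new, unique, unknown or untested is made for them only; others in the source may bear on it.

Measured compounds:
compound 1 `O=C1/C(=C/c2ccccc2F)CN(Cc2cn(Cc3ccccc3F)nn2)C/C1=C\c1ccccc1F` — 41200 nM in an ADME assay on HEK293 cells (Homo sapiens) for cytotoxicity, read by MTT assay, with a stated time of 24 h; on this read-out lower numbers stand for stronger inhibition and higher numbers for weaker inhibition
compound 2 `O=C1/C(=C/c2ccccc2F)CN(Cc2cn(Cc3ccccc3Cl)nn2)C/C1=C\c1ccccc1F` — 33200 nM in this assay
compound 3 `COc1ccc(/C=C2\CN(Cc3cn(Cc4ccccc4Cl)nn3)C/C(=C\c3ccc(OC)cc3)C2=O)cc1` — "not determined" (no result reported) in this assay

Compounds 1 and 2 share one core; compound 3 and the unmeasured compound 4 `COc1ccc(/C=C2\CN(Cc3cn(Cc4ccccc4F)nn3)C/C(=C\c3ccc(OC)cc3)C2=O)cc1` share another. How the two cores differ is not broken down here. Within each pair the single change is the same: from compound 2 to compound 1 it is fluoro in place of chloro on an aromatic carbon, and from compound 3 to compound 4 it is fluoro in place of chloro on an aromatic carbon, with both changes sitting at the same place as described. On the first core this change gave a 1.2-fold higher number from compound 2 to compound 1 (0.09 log units; within the scatter), so the values of compound 2 and compound 1 cannot be told apart. For compound 3 no number exists, so the expectation for compound 4 rests on compounds 1 and 2 alone: the shared change is expected to move the number little, and the two measured cores are assumed to sit in a similar range. Compound 4 is therefore estimated at 36000 nM, most likely between 15000 nM and 90000 nM.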

Compound 4, half-maximal inhibitory concentration: > 100000 nM
Compound 4 gave a limit, no number; the forecaster's own chance of this, stated with the estimate: 25%; at least 2.7-fold (0.44 log units) between middle value and limit.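

Compound 4 gives > 100000 nM in this assay, which is a limit of the assay and not a number. Within the data shown here, with only that limit for compound 4 and no number for compound 3, no step between the two can be read. The compounds shown leave open whether fluoro in place of chloro changes the value on the core of compound 4 as little as it does on the core of compound 1.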